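Swapping the Amine Tail: Compound 4 Judged from Compound 1

The source may hold more compounds than are shown below. What is called first, only, known or untested is meant among the compounds shown, and "the series" means these compounds.

Measured compounds:
compound 1, `CN(C)CCCCCn1c2c(c3ccccc31)C(=O)c1c[n+]([O-])c3ccccc3c1C2=O`: 470 nM
compound 2, `O=C1c2c[n+]([O-])c3ccccc3c2C(=O)c2c1c1ccccc1n2Cc1cn([C@H]2O[C@H](CO)[C@@H](O)[C@H]2O)nn1`: 710 nM
compound 3, `CC1(C)OC[C@H](Cn2cc(Cn3c4c(c5ccccc53)C(=O)c3c[n+]([O-])c5ccccc5c3C4=O)nn2)O1`: 130 nM

In a functional assay on HCT-116 cells (Homo sapiens) for cytotoxicity, read by MTT assay, with a stated time of 72 h (a lower number here means a stronger inhibitor, a higher number a weaker inhibitor), compound 1 gives 470 nM, the second highest of the three numbers. Compound 2 lies within the scatter of compound 1, so no order between them can be read; compound 3 sits a clear distance lower than compound 1, beyond the scatter.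

Compound 4, `CN1CCN(CCCn2c3c(c4ccccc42)C(=O)c2c[n+]([O-])c4ccccc4c2C3=O)CC1`, differs from compound 1 in a single place: 4-methylpiperazin-1-yl in place of 2-(dimethylamino)ethyl on a saturated chain carbon, three bonds along the chain from an aromatic nitrogen. For the measured compounds named here, the only measured step in this set, a 5.5-fold lower number from compound 2 to compound 3 (0.74 log units; beyond the scatter), concerns the substituent on the aromatic nitrogen, a different place in the shared core from the one altered here, and so it offers no direct guidance. Going by the values given here, no measured pair probes the exchange of one amine-bearing tail for another on the saturated chain. The expectation therefore rests on compound 1 itself, with no step beyond the scatter expected, which is what a 1.0-fold lower number from compound 1 to compound 4 (0.02 log units; within the scatter) expresses. Compound 4 is estimated at 450 nM, with a range from 150 nM to 1400 nM.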

Compound 4, half-maximal inhibitory concentration: 560 nM
Compound 4: middle estimate off by 1.2-fold (0.09 log units), on the low side; measured number inside the range.
By their numbers in this assay, from the lowest: compound 3; then compounds 1, 4 and 2 (each within the scatter of the next).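

In this assay the exchange of 2-(dimethylamino)ethyl for 4-methylpiperazin-1-yl gives a 1.2-fold higher number from compound 1 to compound 4 (0.08 log units; within the scatter) and so leaves no readable change. For the compounds shown here, this is the first measured pair at this place, on a saturated chain carbon, and it shows that this position accepts an added six-membered non-aromatic ring in the tail without a readable change in this assay. Nothing at hand bears on why the two tails read alike.

The compounds shown leave open whether a morpholine, a primary amine or a carboxylic acid at the end of the chain would also read alike. They also leave open whether a longer chain carrying 4-methylpiperazin-1-yl would stay within the scatter of compound 4.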